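Ester to acid on the shared core

The compounds below may be only part of what the source reports. "The series", "measured", "known", "first", "only" and "open" are said of these compounds alone.

Compound 2 `CCOC(=O)c1oc2ccc(N(Cc3ccccc3)S(=O)(=O)c3ccc(Cl)cc3)cc2c1C` holds the lowest of the two numbers in a functional assay on HCT-116 cells (Homo sapiens) for inhibition, read by MTT assay, with a stated time of 72 h (a higher number here means a weaker inhibitor, a lower number a stronger inhibitor), giving 4860 nM. Its nearest neighbour, compound 3 `CCOC(=O)c1oc2ccc(N(CC3CCCCC3)S(=O)(=O)c3ccc(Cl)cc3)cc2c1C`, gives 14100 nM in this assay. Compound 1 `CCOC(=O)c1oc2ccc(N(Cc3ccccc3)S(=O)(=O)c3ccccc3Br)cc2c1C` reaches only a limit of this assay, > 40000 nM, and that value is a limit rather than a number (the limit of > 40000 nM in this assay, at which 1 of the 3 values shown sits). The two steps measured so far both sit on the sulfonamide side of the shared core: an at least 8.2-fold lower number from compound 1 to compound 2 (0.91 log units; beyond the scatter), and a 2.9-fold higher number from compound 2 to compound 3 (0.46 log units; beyond the scatter).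

Compound 4 `Cc1c(C(=O)O)oc2ccc(N(Cc3ccccc3)S(=O)(=O)c3ccc(Cl)cc3)cc12` differs from compound 2 at the other end of the molecule, by hydrogen in place of ethyl on an oxygen next to a carbonyl group; read one bond further out, ethoxycarbonyl becomes carboxy. Among the measured compounds shown here, neither measured step touches the ester, so none of them bears directly on this change; the series gives no measured precedent for it. Without a precedent the expectation is cautious: a higher number in this assay for compound 4 than for compound 2, of modest size, a 2.5-fold higher number from compound 2 to compound 4 (0.39 log units; beyond the scatter), with a wide spread that reaches the assay limit. Compound 4 is therefore estimated at 12000 nM in this assay, expected to fall between 3000 nM and 40000 nM.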

Compound 4, half-maximal inhibitory concentration: 9130 nM
Compound 4: middle estimate off by 1.3-fold (0.12 log units), on the high side, and the stated range covers the measured number.
By their numbers in this assay, from the lowest: compounds 2, 4 and 3 (each within the scatter of the next, the first and the last beyond it). At a limit, above all of these: compound 1.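

Notes on the ester position: in this assay this is the first measured step at this end of the shared core, and hydrogen in place of ethyl on an oxygen next to a carbonyl group gives a 1.9-fold higher number from compound 2 to compound 4 (0.27 log units; within the scatter). With the sulfonamide side held as in compound 2, ethoxycarbonyl and carboxy therefore cannot be told apart in this assay, whereas the two steps on the sulfonamide side, an at least 8.2-fold lower number from compound 1 to compound 2 (0.91 log units; beyond the scatter) and a 2.9-fold higher number from compound 2 to compound 3 (0.46 log units; beyond the scatter), are both printed as beyond the scatter, so among the compounds shown the differences beyond the scatter lie on that side only. Nothing shown bears on why this step has the size it has.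

Going by these compounds, this reading rests on a single pair, so it remains open whether the same change gives a similar step with the cyclohexyl group of compound 3 or the 2-bromophenyl group of compound 1. Also open, on these data alone, is how a longer chain on that oxygen, or a primary amide in place of the ester, would read in this assay.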